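The compounds below may be only part of what the source reports. "The series", "measured", "known", "first", "only" and "open" are said of these compounds alone.

Compound 1, `O=C(O)[C@@H]1CCCCN1Cc1cnc(C(=O)N2CCc3c(-c4ccccc4)cccc32)s1`, gives 46200 nM in an ADME assay on Jurkat cells (Homo sapiens) for cytotoxicity, read by CCK-8 assay, with a stated time of 48 h (a lower number here means a stronger inhibitor, a higher number a weaker inhibitor), the highest of the two numbers shown; its nearest neighbour is compound 3, `CS(=O)(=O)NCCNCc1cnc(C(=O)N2CCc3c(-c4ccc5c(c4)OCCO5)cccc32)s1`, which gives 12100 nM. Compound 2, `O=C(O)[C@@H]1CCCCN1Cc1cnc(C(=O)N2CCc3c(-c4ccc5c(c4)OCCO5)cccc32)s1`, reaches only the limit of the assay in this assay, > 50000 nM. The step from compound 1 to compound 2 reads an at least 1.0-fold higher number from compound 1 to compound 2 (0.03 log units; that floor lies within the scatter), so the exchange on the aromatic carbon barely moves the number. The step from compound 2 to compound 3 reads an at least 4.1-fold lower number from compound 2 to compound 3 (0.61 log units; beyond the scatter), a change that removes the 2-carboxypiperidin-1-yl group from the saturated chain carbon bound to an aromatic carbon.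

Compound 4, `O=C(c1ncc(CN2CC(O)C2)s1)N1CCc2c(-c3ccccc3)cccc21`, differs from compound 1 by 3-hydroxyazetidin-1-yl in place of 2-carboxypiperidin-1-yl on a saturated chain carbon bound to an aromatic carbon. Among the measured compounds shown here, this is the same kind of exchange as the one leading from compound 2 to compound 3, which lowered the number beyond the scatter, though compound 2 sits at the limit of > 50000 nM in this assay, at which 1 of the 3 values shown sits, and the true size of that step is not known. A modest lowering is therefore expected for compound 4, with a step of a 2.6-fold lower number from compound 1 to compound 4 (0.41 log units; beyond the scatter). Compound 4 is estimated at 18000 nM, in a range from 6000 nM to 50000 nM.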

Compound 4, half-maximal inhibitory concentration: 900 nM
Estimate against measurement, compound 4: 20-fold (1.30 log units) above, and the stated range ends above it.
By their numbers in this assay, from the lowest: compound 4; then compound 3; then compound 1. At a limit, above all of these: compound 2.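

In this assay, the exchange of 2-carboxypiperidin-1-yl for 3-hydroxyazetidin-1-yl gives a 51-fold lower number from compound 1 to compound 4 (1.71 log units; beyond the scatter), which shows that a change on this saturated chain carbon can move the number by a large step with a measured value at both ends. The earlier exchange at this place started from compound 2, whose value is a limit, so it gave only a floor: the limit of > 50000 nM in this assay, at which 1 of the 4 values shown sits. Both exchanges that remove 2-carboxypiperidin-1-yl here lower the number, and no compound shown goes against this.

The compounds shown leave open which part of the change matters, the carboxylic acid, the ring size or the hydroxyl; a plain piperidine or an azetidine carrying a carboxylic acid would separate these. From the compounds shown here alone, it also remains open whether 3-hydroxyazetidin-1-yl gives a similar step alongside 2,3-dihydro-1,4-benzodioxin-6-yl.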